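This account rests on a few compounds, and the source may have more. Where it says the series, first, only, none or still open, it means among the compounds named here.

In an ADME assay on the whole organism (Mus musculus, strain CD1) for pharmacokinetics, at a dose of 10 mg/kg by the oral route (on this read-out higher numbers stand for higher exposure at the dose given and lower numbers for lower exposure), compound 1 (`COc1cc(N2C(=O)C3(CCC3)N(c3ccc(OC4CCN(C)CC4)nc3)C2=S)cnc1C#N`) gives 1320 nM, compound 2 (`CN1CCC(Oc2ccc(N3C(=S)N(c4cnc(C#N)c(C(F)(F)F)c4)C(=O)C34CCC4)cn2)CC1`) gives 1300 nM and compound 3 (`N#Cc1ncc(N2C(=O)C3(CCC3)N(c3ccc(OC4CCNCC4)cc3)C2=S)cc1Cl`) gives 780 nM, which places compound 2 within the scatter of both others. Compound 4 (`N#Cc1ncc(N2C(=O)C3(CCC3)N(c3ccc(OC4CCNCC4)nc3)C2=S)cc1C(F)(F)F`) departs from compound 2 by hydrogen in place of methyl on an amine nitrogen in a ring. Going by the values given here, no measured step shows this change. Among the compounds with values here, the only measured step, a 1.0-fold lower number from compound 1 to compound 2 (0.01 log units; within the scatter), concerns trifluoromethyl in place of methoxy on an aromatic carbon. The (piperidin-4-yl)oxy group also occurs in compound 3, at 780 nM, though that compound differs elsewhere too. On that single value, a slightly lower number is expected, a 1.6-fold lower number from compound 2 to compound 4 (0.21 log units; within the scatter), not beyond the scatter. Compound 4 is estimated at 800 nM, with an expected range of 350 nM to 1700 nM.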

Compound 4, maximal plasma concentration: 660 nM
The estimate for compound 4 lay 1.2-fold (0.08 log units) above the measured number; the range from low to high includes it.
By their numbers in this assay, from the lowest: compounds 4, 3, 2 and 1 (each within the scatter of the next).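

In this assay, the exchange of methyl for hydrogen on the amine nitrogen of the ring now has a direct reading, a 2.0-fold lower number from compound 2 to compound 4 (0.29 log units; within the scatter), with the rest of the molecule unchanged. On this single pair, the (1-methylpiperidin-4-yl)oxy and (piperidin-4-yl)oxy groups cannot be told apart, which compound 3 could not show as it differs elsewhere too. Nothing here bears on the reason for this result. Going by these compounds, whether an ethyl or acetyl group on this nitrogen would give a step beyond the scatter remains open.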